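The compounds below may be only part of what the source reports. "The series", "measured", "known", "first", "only" and "open" are said of these compounds alone.

Compound 1, `Cc1ccc(S(=O)(=O)N2CCC(N3CCC(C)CC3)CC2)cc1C`, in an ADME assay on HCT-116 cells (Homo sapiens) for cytotoxicity, read by CellTiter-Glo, with a stated time of 72 h; on this read-out higher numbers stand for weaker inhibition and lower numbers for stronger inhibition: > 5000 nM
Compound 2, `CC1CCN(C2CCN(S(=O)(=O)c3ccc(Cl)cc3Cl)CC2)CC1`: > 5000 nM
Compound 3, `COc1cccc(S(=O)(=O)N2CCC(N3CCC(C)CC3)CC2)c1`: > 5000 nM

In this assay compound 1 gives > 5000 nM, which is a limit of the assay and not a number. Compound 2 gives > 5000 nM, again a limit. Compound 3 gives > 5000 nM, also a limit, so all three sit at the limit of > 5000 nM in this assay, at which 3 of the 3 values shown sit, and none of them shows measurable cytotoxicity on these cells.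

The change leading to compound 4, `CC1CCN(C2CCN(S(=O)(=O)c3ccc(Br)c(Cl)c3)CC2)CC1`, is 4-bromo-3-chlorophenyl in place of 3-methoxyphenyl on a sulfonyl sulfur. The steps already measured on the same sulfonyl sulfur bear on it: a step that the two limits leave unreadable from compound 1 to compound 2, a step that the two limits leave unreadable from compound 1 to compound 3 and a step that the two limits leave unreadable from compound 2 to compound 3. None of them can be read, since each pair of values is a pair of limits. Within the data shown here, compound 2 already carries two chlorines on that ring and stays at the limit, so nothing among the measured compounds points to a step beyond the scatter in this assay. Compound 4 is therefore expected to stay at the limit as well, the expected step being a step that the limit leaves unreadable from compound 3 to compound 4, and its estimated value is 8000 nM with a range from 3000 nM to 30000 nM.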

Compound 4, half-maximal inhibitory concentration: > 5000 nM
Compound 4: a limit, no number; the forecaster's own chance of this, stated with the estimate: 80%; the middle value is on the limit's open side.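

Compound 4 gives > 5000 nM in this assay, which is a limit and not a number. Its steps from compound 1, compound 2 and compound 3 cannot be read, as each joins two limits. The compounds shown leave open whether any aromatic group on the sulfonyl sulfur would give a measurable value, because all of them share one limit: the limit of > 5000 nM in this assay, at which 4 of the 4 values shown sit.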